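Sulfur-linked aryl ether analogues: a ring swap on the sulfur

The compounds below may be only part of what the source reports. "The series", "measured", "known", "first", "only" and "open" are said of these compounds alone.

Measured compounds:
compound 1 `Nc1cc(N)c2nc(-c3ccccc3)c(Oc3ccc(Cl)c(Cl)c3)nc2c1`: 49000 nM
compound 2 `Nc1cc(N)c2nc(-c3ccccc3)c(Sc3ccc(Cl)c(Cl)c3)nc2c1`: 9120 nM

Two compounds share a core and differ only in the group on one aromatic carbon. In a functional assay on NCI-H226 cells (Homo sapiens) for inhibition, read by sulforhodamine B assay, with a stated time of 48 h (a lower number here means a stronger inhibitor of growth, a higher number a weaker inhibitor of growth), compound 1 gives 49000 nM, while compound 2 gives 9120 nM. Within the data shown here, the change a 5.4-fold lower number from compound 1 to compound 2 (0.73 log units; beyond the scatter) is the only measured step here. Among the measured compounds shown here, compound 2 thus holds the lower of the two numbers in this assay, with compound 1 as its only neighbour.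

Compound 3 `Nc1cc(N)c2nc(-c3ccccc3)c(Sc3ccc(F)cc3)nc2c1` is not yet measured. It differs from compound 2 in that (4-fluorophenyl in place of 3,4-dichlorophenyl on a sulfur). For the measured compounds named here, no measured step bears on this change: the single step, from compound 1 to compound 2, concerns the atom joining the ring to the core, not the ring itself. The expectation therefore rests on compound 2 alone, with wide uncertainty. A step of a 2.2-fold higher number from compound 2 to compound 3 (0.34 log units; beyond the scatter) is expected, toward a somewhat higher number, though a result within the scatter would not surprise. Compound 3 is estimated at 20000 nM, in a range of 5000 nM to 80000 nM.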

Compound 3, concentration for total growth inhibition: 46800 nM
Compound 3: middle estimate off by 2.3-fold (0.37 log units), on the low side; low and high end bracket the measured number.
By their numbers in this assay, from the lowest: compound 2; then compounds 3 and 1 (each within the scatter of the next).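

The result shows that the ring on the sulfur matters as well as the atom joining it to the core. In this assay, 4-fluorophenyl in place of 3,4-dichlorophenyl on the sulfur gives a 5.1-fold higher number from compound 2 to compound 3 (0.71 log units; beyond the scatter), a step close in size to the one at the linking atom, a 5.4-fold lower number from compound 1 to compound 2 (0.73 log units; beyond the scatter). The advantage of compound 2 therefore cannot be credited to the sulfur link alone, since sulfur-linked compound 3 and oxygen-linked compound 1 stand level, with a 1.0-fold lower number from compound 1 to compound 3 (0.02 log units; within the scatter), and no measurement at hand explains this dependence on the ring.

The swap changes the halogens and their number together, so these compounds do not separate the contribution of each chlorine from that of the fluorine, a question that a plain phenyl or a phenyl carrying a single chlorine on the sulfur could address. On these data alone, whether the link and the ring act independently also remains open, and the 4-fluorophenyl ring on an oxygen link would test this directly.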